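Adding Fluorine to a Phenylpiperazine Antiproliferative Amide

A few compounds are considered here, and "the series" means these few. Any claim that something is new, unique, unknown or untested is made for them only; others in the source may bear on it.

Compound 1, `Nc1ccccc1NC(=O)c1ccc(CSC(=S)N2CCN(c3ccccc3)CC2)cc1`, was tested in a functional assay on MGC-803 cells (Homo sapiens) for antiproliferative activity, read by CCK-8 assay, with a stated time of 72 h, tested at 2 uM (on this read-out lower numbers stand for a weaker effect and higher numbers for a stronger effect at the one concentration tested), and gave 42.3%. Compound 2, `Nc1ccccc1NC(=O)c1ccc(CSC(=S)N2CCCc3ccccc32)cc1`, gave 38.5% in this assay. Among the compounds with values here, of these two numbers, the one for compound 1 is the larger, yet the gap between them lies within the usual scatter of repeated measurements, so the two compounds cannot be told apart on this read-out. Within the data shown here, no pair of measured compounds differing in a single place is at hand, so there is nothing yet to show how one small change moves this read-out.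

Compound 3, `Nc1ccccc1NC(=O)c1ccc(CSC(=S)N2CCN(c3ccc(F)cc3)CC2)cc1`, differs from compound 1 by fluoro in place of hydrogen on an aromatic carbon. Among the measured compounds shown here, with no measured step to lean on, the expected step of a number 1.7 percentage points higher from compound 1 to compound 3 (within the scatter) is small and not beyond the scatter, in no particular direction. Compound 3 is therefore estimated to give about 44% in this assay, with a likely range from 30% to 60%.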

Compound 3, a percentage reported as inhibition, at one concentration (the size of the read-out at that concentration, not a potency): 18.8%
The estimate for compound 3 lay 25.2 percentage points above the measured number; measured number below the stated range.
By their numbers in this assay, from the lowest: compound 3; then compounds 2 and 1 (each within the scatter of the next).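

In this assay, replacing phenyl with 4-fluorophenyl gives a number 23.5 percentage points lower from compound 1 to compound 3 (beyond the scatter). This single replacement shows that the aromatic carbon para to a large group is not a neutral place to change: adding one fluoro, a single heavy atom, is enough to weaken the effect at the one concentration tested. No measurement available here accounts for this drop.

On these data alone, it remains open whether the drop is specific to fluoro or would also follow from another group on this carbon, such as chloro, methoxy or an amine, and whether fluoro on a different carbon of the same ring would do the same. As far as these compounds go, because the read-out comes from one concentration, the gap in potency between compound 1 and compound 3 also remains open.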